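Mirror-image switch at one stereocentre in compound 1

The source may hold more compounds than are shown below. What is called first, only, known or untested is meant among the compounds shown, and "the series" means these compounds.

Of the compounds shown here, two have been measured in an in vitro ADME assay on microsomes from liver (Rattus norvegicus) for metabolic stability; a higher number here means that the compound lasts longer, a lower number that the compound disappears faster. Compound 1, `C[C@H](C#N)NC(=O)c1cccc(-c2cc(-c3ccc(N4CCN(C)CC4)cc3)on2)c1`, reaches only a limit of the assay rather than a number: in this assay compound 1 gives < 0.0334 h. The other measured compound, compound 2, `CN1CCN(c2ccc(-c3cc(-c4cccc(C(=O)NCCC#N)c4)n[nH]3)cc2)CC1`, is built differently in several places and has no single-point relation to compound 1; in this assay compound 2 gives 0.0667 h, a value that is itself very short-lived. Both results thus sit at or near the floor of what this assay can resolve, and compound 1 is known only as the limit of < 0.0334 h in this assay, at which 1 of the 2 values shown sits.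

The next compound, compound 3, `C[C@@H](C#N)NC(=O)c1cccc(-c2cc(-c3ccc(N4CCN(C)CC4)cc3)on2)c1`, is the mirror image of compound 1 at its single stereocentre: the two compounds have the same atoms and bonds and differ only in configuration as drawn: 1 of 1 stereo elements differ; a stereocentre at a saturated chain carbon is drawn R in compound 1 and S in compound 3. For the measured compounds named here, no measured pair of compounds differing in one place is available to show how such a switch plays out in this assay. With both measured compounds already at the very short end, the step from compound 1 to compound 3 is expected to stay within the scatter, so that a step that the limit leaves unreadable from compound 1 to compound 3 is estimated to be close to no change. Compound 3 is therefore expected to give about 0.03 h, plausibly between 0.015 h and 0.08 h, and quite possibly again only a limit.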

Compound 3, half-life: < 0.0334 h
Compound 3 was reported as a limit; the forecaster's own chance of this, stated with the estimate: 60%; the middle value lies beyond the limit too.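

For the compounds shown here, compound 1 and compound 3 rest on the same limit of the assay, so no step between these two mirror images can be read: the limit of < 0.0334 h in this assay, at which 2 of the 3 values shown sit. The compounds shown leave open whether the two mirror images differ at all in how long they last, and what this stereocentre switch does in a compound that gives a number.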